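From 2-fluorophenyl to 4-fluorophenyl in compound 2

This account rests on a few compounds, and the source may have more. Where it says the series, first, only, none or still open, it means among the compounds named here.

Compound 2 `COc1cccc(CNCc2c(C(=O)O)n(Cc3ccccc3F)c3ccccc23)c1` gives > 50000 nM in a functional assay on Bel-7402 cells (Homo sapiens) for antiproliferative activity, read by MTT assay, with a stated time of 72 h (a lower number here means a stronger inhibitor, a higher number a weaker inhibitor), and this value is a limit of the assay, not a number. Compound 1 `COc1cccc(CNCc2c(C(=O)O)n(Cc3ccc(C)cc3)c3ccccc23)c1`, which carries 4-methylphenyl at the same place, gives 21500 nM in this assay.

Compound 3 `COc1cccc(CNCc2c(C(=O)O)n(Cc3ccc(F)cc3)c3ccccc23)c1` has the same atoms as compound 2, joined differently: 4-fluorophenyl in place of 2-fluorophenyl on a saturated chain carbon bound to an aromatic nitrogen. In words, 4-fluorophenyl stands in place of 2-fluorophenyl on a saturated chain carbon bound to an aromatic nitrogen.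

Among the measured compounds shown here, only one measured step bears on this change: an at least 2.3-fold higher number from compound 1 to compound 2 (0.36 log units; beyond the scatter). It is at least modest and lies beyond the scatter. That step replaces 4-methylphenyl with 2-fluorophenyl, so it cannot show what the fluorine's new place alone will do. Compound 3 does, however, resemble compound 1, with its value of 21500 nM, in having a 4-substituted phenyl group. A modest move towards a lower number is therefore expected, with real uncertainty. The expected step is an at least 1.6-fold lower number from compound 2 to compound 3 (0.22 log units; that floor lies within the scatter). For compound 3 the estimated value is 30000 nM, with an expected range from 12000 nM to 60000 nM.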

Compound 3, half-maximal inhibitory concentration: > 50000 nM
Compound 3 was reported as a limit (the forecaster's own chance of this, stated with the estimate: 35%); at least 1.6-fold (0.22 log units) between middle value and limit.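

In this assay compound 3 gives > 50000 nM, which is a limit of the assay. Among the compounds shown here, its comparison with compound 1 is the first to isolate a single change on the aromatic ring of the benzyl group, with the group's place held constant: fluoro in place of methyl on an aromatic carbon gives an at least 2.3-fold higher number from compound 1 to compound 3 (0.36 log units; beyond the scatter), so within this set a number is retained only with 4-methylphenyl, and 4-fluorophenyl joins 2-fluorophenyl at the limit. The step from compound 2 to compound 3 cannot be read, so the two fluorine placements cannot be told apart here, and the only reading available is that they share one ceiling: the limit of > 50000 nM in this assay, at which 2 of the 3 values shown sit.

Going by these compounds, what remains open is how far compound 2 and compound 3 each lie beyond that limit, and so whether moving the fluorine from 2-fluorophenyl to 4-fluorophenyl changes anything at all. On these data alone, it is also open whether the number seen for compound 1 depends on methyl specifically, or would persist with ethyl, methoxy or chloro on that aromatic carbon.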